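Ribose-linked fused cores: ethynyl in place of thiophen-2-yl

The compounds below may be only part of what the source reports. "The series", "measured", "known", "first", "only" and "open" are said of these compounds alone.

Compound 1, `COc1ncnc2c1c(-c1cc3ccccc3o1)cn2[C@@H]1O[C@H](CO)[C@@H](O)[C@H]1O`: 14500 nM
Compound 2, `Cc1nc(N)c2c(-c3cccs3)cn([C@@H]3O[C@H](CO)[C@@H](O)[C@H]3O)c2n1`: > 20000 nM (a limit of the assay, not a number)

Both values come from a functional assay on HCT-116 cells (Homo sapiens), read by MTT assay, with a stated time of 72 h; a lower number here means a stronger inhibitor, a higher number a weaker inhibitor. Compound 1 gives 14500 nM. For compound 2 the assay returned only a limit, > 20000 nM, so no number stands for it. On the numbers shown compound 2 sits at the limit of > 20000 nM in this assay, at which 1 of the 2 values shown sits. Compounds 1 and 2 differ in more than one place, so nothing beyond their two values is read from the pair.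

Compound 3 is `C#Cc1cn([C@@H]2O[C@H](CO)[C@@H](O)[C@H]2O)c2nc(C)nc(N)c12`. It differs from compound 2 in one place: ethynyl in place of thiophen-2-yl on an aromatic carbon. Among the measured compounds shown here, no step between measured compounds bears on this change; the only anchor is compound 2 at its limit. In this assay no shift beyond the usual scatter is expected from compound 2 to compound 3, and the reported value is expected most likely to be a limit again. Compound 3 is estimated at 30000 nM, within 8000 nM to 120000 nM, which corresponds to an expected step that the limit leaves unreadable from compound 2 to compound 3.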

Compound 3, half-maximal inhibitory concentration: > 20000 nM
Compound 3: only a limit was reported (the forecaster's own chance of this, stated with the estimate: 70%); the middle value is on the limit's open side.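

Among the compounds shown here, no step from compound 2 to compound 3 can be read, since each returns only a limit of the assay in this assay: the limit of > 20000 nM in this assay, at which 2 of the 3 values shown sit. The compounds shown leave open how far ethynyl and thiophen-2-yl on this aromatic carbon differ in this assay, as neither compound has a number there.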